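Compound 4: bromo in place of the fluorophenylethenyl arm

The source may hold more compounds than are shown below. What is called first, only, known or untested is meant among the compounds shown, and "the series" means these compounds.

Compound 1 `COC(=O)/C=C/c1cccc(N(Cc2ccc(/C=C/c3cccc(F)c3)cc2)C(=O)C2CCCCC2)c1` is measured in an assay on isolated protein with Bile acid receptor (Homo sapiens) as the target (a higher number here means that more compound is needed for the effect, a lower number that less compound is needed), and gives 86 nM. Among the three measured compounds this is the second highest number. Compound 2 `COC(=O)/C=C/c1cccc(N(Cc2ccc(/C=C/c3cccc(F)c3)cc2)C(=O)C(C)C)c1` gives 71 nM, and the step of a 1.2-fold lower number from compound 1 to compound 2 (0.08 log units; within the scatter) lies within the scatter. Compound 3 `COC(=O)/C=C/c1cccc(N(Cc2ccc(-c3ccc(C)cc3)cc2)C(=O)NC(C)C)c1` gives 449 nM; its number is higher than that of compound 1, and the gap is beyond the scatter, but compound 3 differs from compound 1 in two places, so it is not a single step.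

Compound 4 `COC(=O)/C=C/c1cccc(N(Cc2ccc(Br)cc2)C(=O)C2CCCCC2)c1` differs from compound 1 as follows: bromo in place of 2-(3-fluorophenyl)ethenyl on an aromatic carbon. Going by the values given here, no measured step touches this part of the molecule; the only single step known, a 1.2-fold lower number from compound 1 to compound 2 (0.08 log units; within the scatter), concerns the group on the carbonyl carbon and is small. Among the compounds with values here, the change to compound 4 removes a large part of compound 1, and no measured compound shows what a group this small gives there. For compound 4 a higher number is expected, a step of a 17-fold higher number from compound 1 to compound 4 (1.24 log units; beyond the scatter) beyond the scatter, with wide uncertainty. The estimate for compound 4 is 1500 nM, ranging from 300 nM to 8000 nM.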

Compound 4, half-maximal effective concentration: > 1000 nM
Compound 4: only a limit was reported (the forecaster's own chance of this, stated with the estimate: 15%); the middle value is on the limit's open side.
By their numbers in this assay, from the lowest: compounds 2 and 1 (each within the scatter of the next); then compound 3. At a limit, above all of these: compound 4.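

Of the changes shown, this is the first at the aromatic carbon carrying the 2-(3-fluorophenyl)ethenyl arm, and in this assay it matters far more than the change on the carbonyl carbon: bromo there gives an at least 11-fold higher number from compound 1 to compound 4 (1.06 log units; beyond the scatter), whereas isopropyl for cyclohexyl gives a 1.2-fold lower number from compound 1 to compound 2 (0.08 log units; within the scatter). Compound 4 reads > 1000 nM, which is a limit of the assay and not a number. The step therefore has only a lower bound, and its full size cannot be read: the limit of > 1000 nM in this assay, at which 1 of the 4 values shown sits.

Which part of the arm counts remains open: an unsubstituted phenyl, a 2-phenylethenyl arm without fluorine, or a saturated two-carbon link in place of the ethenyl would help to separate the contributions. From the compounds shown here alone, it is also open how this arm loss would read with isopropyl on the carbonyl carbon, or with a carboxylic acid in place of the methyl ester.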